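From amino to bromo on the shared core

This account rests on a few compounds, and the source may have more. Where it says the series, first, only, none or still open, it means among the compounds named here.

Compound 1 `C/C(=N\NC(=O)c1ccc(C(F)(F)F)cc1)c1cnccn1`: 2090 nM
Compound 2 `C/C(=N\NC(=O)c1ccc(O)cc1)c1cnccn1`: > 80000 nM
Compound 3 `C/C(=N\NC(=O)c1ccc(N)cc1)c1cnccn1`: > 80000 nM

In an ADME assay on MRC5 cells (Homo sapiens) for antiproliferative activity, read by MTT assay (a lower number here means a stronger inhibitor, a higher number a weaker inhibitor), compound 3 gives > 80000 nM, which is a limit and not a number. Compound 2 gives > 80000 nM, which is likewise a limit. Compound 3 therefore stands at the limit of > 80000 nM in this assay, at which 2 of the 3 values shown sit.

Compound 4 `C/C(=N\NC(=O)c1ccc(Br)cc1)c1cnccn1` carries bromo in place of amino on an aromatic carbon, para to a large group: bromo in place of amino on an aromatic carbon.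

For the measured compounds named here, two measured steps bear on this change, and both replace trifluoromethyl at that place. One is an at least 38-fold higher number from compound 1 to compound 2 (1.58 log units; beyond the scatter). The other is an at least 38-fold higher number from compound 1 to compound 3 (1.58 log units; beyond the scatter). Both are large and beyond the scatter, while a step that the two limits leave unreadable from compound 2 to compound 3. Bromo is neither hydroxy nor amino, so compound 4 is expected to fall nearer compound 1, which gives 2090 nM. This reasoning rests on compound 1 alone. A large move towards a lower number, and so a stronger inhibitor, is expected in this assay. The expected step is an at least 20-fold lower number from compound 3 to compound 4 (1.30 log units; beyond the scatter). Compound 4 is estimated at 4000 nM, with an expected range of 1200 nM to 20000 nM.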

Compound 4, half-maximal inhibitory concentration in the MRC5 assay: 2940 nM
Estimate against measurement, compound 4: 1.4-fold (0.13 log units) above, within the range that was stated.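

For the compounds shown here, in the MRC5 assay, bromo in place of amino gives an at least 27-fold lower number from compound 3 to compound 4 (1.43 log units; beyond the scatter), and bromo in place of hydroxy gives an at least 27-fold lower number from compound 2 to compound 4 (1.43 log units; beyond the scatter), so trifluoromethyl is no longer the only group at this place with a value that can be read as a number. Bromo in place of trifluoromethyl gives a 1.4-fold higher number from compound 1 to compound 4 (0.15 log units; within the scatter), so compound 1 and compound 4 cannot be told apart in this assay. In a physicochemical assay for lipophilicity (a higher number here means a more lipophilic compound, a lower number a more polar compound), compound 3 gives 1.3 and compound 4 gives 2.9. The change from amino to bromo also comes with a rise in lipophilicity, which may be tied to the gain in the MRC5 assay, although a single pair cannot settle that: the measured partition coefficient of compound 3, 1.3, and of compound 4, 2.9, a number 1.60 log units higher (beyond the scatter)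

Going by these compounds, what a chloro, methyl or methoxy group would give at this place remains open. On these data alone, whether the link with lipophilicity holds beyond this pair also remains open, as only compound 3 and compound 4 have a partition coefficient here.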